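A few compounds are considered here, and "the series" means these few. Any claim that something is new, unique, unknown or untested is made for them only; others in the source may bear on it.

Measured in an ADME assay on microsomes from liver (Mus musculus) for pharmacokinetics, read by LC-MS, using NADPH, with stated times of 5 min, 15 min and 30 min, tested at 10 uM (on this read-out higher numbers stand for fast clearance and lower numbers for slow clearance), where every value is a limit of the assay and not a number:

compound 1 `C[C@H](NC(=O)c1ncccn1)c1ccc(NC(=O)N2CC(c3ccc(N)nc3)C2)cc1` gives < 25 mL.min-1.g-1
compound 2 `C[C@H](NC(=O)C1CCOCC1)c1ccc(NC(=O)N2CC(c3ccc(N)nc3)C2)cc1` gives < 25 mL.min-1.g-1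
compound 3 `C[C@H](NC(=O)[C@@H]1CCCN1C)c1ccc(NC(=O)N2CC(c3ccc(N)nc3)C2)cc1` gives < 25 mL.min-1.g-1

Compound 2 stands at < 25 mL.min-1.g-1, which is a limit and not a number. The whole set offers only (the limit of < 25 mL.min-1.g-1 in this assay, at which 3 of the 3 values shown sit).

Compound 4 `C[C@H](NC(=O)C1CCOCC1)c1ccc(NC(=O)N2CC(c3cncc(N)c3)C2)cc1` has the same atoms as compound 2, joined differently: 5-aminopyridin-3-yl in place of 6-aminopyridin-3-yl on a saturated ring carbon. It carries 5-aminopyridin-3-yl in place of 6-aminopyridin-3-yl on a saturated ring carbon. The measured changes are a step that the two limits leave unreadable from compound 1 to compound 2, a step that the two limits leave unreadable from compound 1 to compound 3 and a step that the two limits leave unreadable from compound 2 to compound 3, all of them at the group on a carbonyl carbon, so none gives a size for this change.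

Resting on compound 2 at < 25 mL.min-1.g-1 as a limit, no step beyond the scatter is expected in this assay, in either direction. The expected step is a step that the limit leaves unreadable from compound 2 to compound 4. For compound 4 the estimated value is 20 mL.min-1.g-1, with an expected range from 10 mL.min-1.g-1 to 45 mL.min-1.g-1.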

Compound 4, intrinsic clearance in microsomes: 60.2 mL.min-1.g-1
For compound 4 the middle estimate is 3.0-fold (0.48 log units) below the measured one, outside the stated range (above it).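

In this assay, 5-aminopyridin-3-yl in place of 6-aminopyridin-3-yl on a saturated ring carbon of the four-membered non-aromatic ring gives an at least 2.4-fold higher number from compound 2 to compound 4 (0.38 log units; beyond the scatter), so this position tells the two groups apart although their atoms and counts are the same. For the compounds shown here, the steps among compound 1, compound 2 and compound 3, all at the group on a carbonyl carbon, cannot be read, which makes this the first change in the set with a readable size. Compound 4 alone stands clear of the limit shared by the others: the limit of < 25 mL.min-1.g-1 in this assay, at which 3 of the 4 values shown sit.

The compounds shown leave open whether this step holds with pyrimidin-2-yl or 1-methylpyrrolidin-2-yl on the carbonyl carbon, as it is seen here only with oxan-4-yl. They also leave open how a plain pyridin-3-yl or a 5-methoxypyridin-3-yl would read on the same saturated ring carbon.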